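Trimming the side chain on a brominated diaryl ether

The source may hold more compounds than are shown below. What is called first, only, known or untested is meant among the compounds shown, and "the series" means these compounds.

Compound 1 `CN1CCN(CCCCCOc2c(Br)cc(Br)cc2Oc2ccc(Br)cc2Br)CC1`: 48.3 ug/mL
Compound 2 `Brc1ccc(Oc2cc(Br)cc(Br)c2OCCCCCN2CCN(c3ccccc3)CC2)c(Br)c1`: 41.6 ug/mL
Compound 3 `OCCCOc1c(Br)cc(Br)cc1Oc1ccc(Br)cc1Br`: 29.9 ug/mL

All three were tested in a functional assay on HL-60 cells (Homo sapiens) for cytotoxicity, read by MTT assay, with a stated time of 24 h; a lower number here means a stronger inhibitor, a higher number a weaker inhibitor. Compound 3 lies within the scatter of both other numbers, so the three cannot be separated on this evidence. Compound 4 `COc1c(Br)cc(Br)cc1Oc1ccc(Br)cc1Br` differs from compound 3 by hydrogen in place of 2-hydroxyethyl on a saturated chain carbon bound to an oxygen on an aromatic ring. For the measured compounds named here, no measured step matches this change directly. The closest guide is a 1.6-fold lower number from compound 1 to compound 3 (0.21 log units; within the scatter), where a large change at the end of the chain barely moved the number, and a 1.2-fold lower number from compound 1 to compound 2 (0.06 log units; within the scatter) was also within the scatter. Compound 4 is therefore expected to stay close, with a step of a 1.1-fold higher number from compound 3 to compound 4 (0.03 log units; within the scatter) in this assay. The estimate for compound 4 is 32 ug/mL, expected to fall between 14 ug/mL and 75 ug/mL.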

Compound 4, half-maximal inhibitory concentration: 28.2 ug/mL
Beside the measured number, compound 4's estimate is 1.1-fold (0.05 log units) above it, and the stated range covers the measured number.
By their numbers in this assay, from the lowest: compounds 4, 3, 2 and 1 (each within the scatter of the next).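

In this assay, cutting 3-hydroxypropoxy down to methoxy gives a 1.1-fold lower number from compound 3 to compound 4 (0.03 log units; within the scatter), so even removing nearly all of the chain leaves no change that can be told from scatter. The earlier compounds shown here all carried a chain of three or more carbons on this oxygen, whereas compound 4 shows that a single methyl group serves about as well in this test. Nothing here explains why the number holds steady.

Still open, on these data alone, is whether a carboxylic acid at the end of the chain would give a number beyond the scatter. The same question applies to a bare hydroxy group in place of the methoxy.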